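Thiosemicarbazone hydrazone variation and growth inhibition of colon cells

The compounds below may be only part of what the source reports. "The series", "measured", "known", "first", "only" and "open" are said of these compounds alone.

Measured compounds:
compound 1 `COc1ccc(/C=N\NC(=S)NC(C)(C)CCC[C@](C)(O)[C@@H]2CC=C(C)CC2)cc1` — 7420 nM
compound 2 `CC1=CC[C@@H]([C@@](C)(O)CCCC(C)(C)NC(=S)N/N=C\c2ccccc2Cl)CC1` — 23700 nM

Of the compounds shown here, two sharing the same core have been tested in a functional assay on HT-29 cells (Homo sapiens) for cytotoxicity, read by sulforhodamine B assay; on this read-out lower numbers stand for stronger inhibition of growth and higher numbers for weaker inhibition of growth. Compound 1 gives 7420 nM in this assay, and compound 2 gives 23700 nM, the higher of the two numbers. For the measured compounds named here, the single measured step between them is a 3.2-fold higher number from compound 1 to compound 2 (0.50 log units; beyond the scatter).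

Compound 3 `CC1=CC[C@@H]([C@@](C)(O)CCCC(C)(C)NC(=S)N/N=C(/C)c2ccccc2)CC1` is not yet measured. It differs from compound 2 in that (a group of 9 heavy atoms (8 carbon, 1 nitrogen; one six-membered aromatic ring of carbon only) in place of a group of 9 heavy atoms (7 carbon, 1 nitrogen, 1 chlorine; one six-membered aromatic ring of carbon only), on an amide-type nitrogen). Going by the values given here, the only measured step concerns a different exchange on the aromatic ring and gives no direct guide to adding a methyl on the carbon with a double bond to nitrogen while removing the chlorine. Since compound 2 stands highest, a somewhat lower number is expected but with wide uncertainty: the expected step is a 2.0-fold lower number from compound 2 to compound 3 (0.30 log units; within the scatter), and compound 3 is estimated at 12000 nM, within a range of 4000 nM to 35000 nM.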

Compound 3, concentration for 50% growth inhibition: 28400 nM
Compound 3: middle estimate off by 2.4-fold (0.37 log units), on the low side; low and high end bracket the measured number.
By their numbers in this assay, from the lowest: compound 1; then compounds 2 and 3 (each within the scatter of the next).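

In this assay the exchange on the amide-type nitrogen whose other neighbour is the thiocarbonyl carbon gives a 1.2-fold higher number from compound 2 to compound 3 (0.08 log units; within the scatter) and so adding a methyl on the carbon with a double bond to nitrogen while removing the chlorine leaves the two compounds indistinguishable. The step of a 3.8-fold higher number from compound 1 to compound 3 (0.58 log units; beyond the scatter) shows that compound 1, with its 4-methoxyphenyl, stands apart from both compounds lacking that group. Nothing available explains these numbers.

On these data alone, because compound 3 carries both changes at once, what the methyl and the loss of the chlorine each contribute stays open. Also open, as far as these compounds go, is how an amine or a carboxylic acid on the aromatic ring would compare with the 4-methoxy group of compound 1.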